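A second chloro on the core of compound 1

The source may hold more compounds than are shown below. What is called first, only, known or untested is meant among the compounds shown, and "the series" means these compounds.

In a functional assay on HepG2 cells (Homo sapiens) for inhibition, read by crystal violet staining, with a stated time of 48 h (a lower number here means a stronger inhibitor, a higher number a weaker inhibitor), compound 1 (`CCn1sc(Cl)cc1=O`) gives 12000 nM. Compound 2 (`COC(=O)CCn1sc(Cl)cc1=O`), which carries methoxycarbonyl in place of a hydrogen on the chain, gives 24000 nM. The measured step is a 2.0-fold higher number from compound 1 to compound 2 (0.30 log units; within the scatter), so these two values cannot be told apart. Compound 3 (`CCn1c(=O)cc(Cl)[s+]1[O-]`) gives only a limit of the assay, > 100000 nM.

Compound 4 (`CCn1sc(Cl)c(Cl)c1=O`) departs from compound 1 in one place: chloro in place of hydrogen on an aromatic carbon. The new chloro replaces a hydrogen on an aromatic carbon, next to the ring atom that bears a chloro group. Among the compounds with values here, no measured step touches this carbon. The closest evidence is the chain change above, and it sits elsewhere in the molecule and stayed within the scatter. That gives only weak guidance on size and none on direction, so no step beyond the scatter is expected in this assay. The expected change is a 1.5-fold lower number from compound 1 to compound 4 (0.18 log units; within the scatter), and a real move either way remains possible. For compound 4 the estimated value is 8000 nM. The range is kept wide for this untested position, with the expected value lying between 2500 nM and 25000 nM.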

Compound 4, half-maximal inhibitory concentration: 12000 nM
The estimate for compound 4 lay 1.5-fold (0.18 log units) below the measured number; the measured number falls inside the stated range.
By their numbers in this assay, from the lowest: compounds 1, 4 and 2 (each within the scatter of the next). At a limit, above all of these: compound 3.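

In this assay, the reading at this aromatic carbon is no change at the digits printed from compound 1 to compound 4 (within the scatter), which gives the only direct look at this position among the compounds shown. The hydrogen here can therefore give way to a chloro, even one placed next to the ring atom that bears a chloro group, without any change that can be told from ordinary repeat-to-repeat variation in this cell assay. This is the second single change to the core of compound 1 that stays within the scatter, the first being the methoxycarbonyl on the chain, and nothing at hand offers a reason for this result.

The compounds shown leave open whether a methyl, a fluoro, an amine or a carboxylic acid on this same aromatic carbon would also leave the number where it stands, since a single group cannot show how much this position tolerates. Also open, going by these compounds, is whether the second chloro would behave the same way with the methoxycarbonyl chain of compound 2 in place of the ethyl group.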